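Triazole oxime ethers: estimate for compound 4

The source may report more compounds than this note shows. Statements on the series, on what has been measured and on what is new or still open speak of the compounds shown alone.

Measured so far:
compound 1 `COc1ccc([C@@H]2C/C(=N/OCc3cn(-c4ccc(Cl)cc4C)nn3)c3cc(CC=C(C)C)c(OC)cc3O2)cc1` — 20%
compound 2 `COc1ccc([C@@H]2C/C(=N/OCc3cn(-c4ccccc4CO)nn3)c3cc(CC=C(C)C)c(OC)cc3O2)cc1` — 100%
compound 3 `COc1cc2c(cc1CC=C(C)C)C(=O)C[C@@H](c1ccc(Oc3ccc(F)cc3)cc1)O2` — 29%

In a functional assay on HCT-116 cells (Homo sapiens) for inhibition, read by sulforhodamine B assay, with a stated time of 48 h, tested at 50 uM (a higher number here means more inhibition of growth at the concentration tested, a lower number less inhibition of growth), compound 2 gives 100%, the highest of the three numbers, beyond the scatter against both others. Compound 3 gives 29% and compound 1 gives 20%. Among the compounds with values here, the one step known, a number 80 percentage points higher from compound 1 to compound 2 (beyond the scatter), is large and shows that the group on the aromatic nitrogen sets the level.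

Compound 4 `COc1ccc([C@@H]2C/C(=N/OCc3cn(-c4cccc(CO)c4)nn3)c3cc(CC=C(C)C)c(OC)cc3O2)cc1` differs from compound 2 only there: 3-(hydroxymethyl)phenyl in place of 2-(hydroxymethyl)phenyl on an aromatic nitrogen. Within the data shown here, no measured step exchanges one hydroxymethylphenyl for another, so the direction is uncertain; the number for compound 2 cannot rise, and the only bearing step was large. A downward step of moderate size is expected, a number 25 percentage points lower from compound 2 to compound 4 (beyond the scatter). Compound 4 is estimated at 75%, between 35% and 100%.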

Compound 4, percent growth inhibition at one concentration: 27%
Estimate against measurement, compound 4: 48 percentage points above; the measured number lies below the stated range.
By their numbers in this assay, from the lowest: compounds 1, 4 and 3 (each within the scatter of the next); then compound 2.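

In this assay, moving the hydroxymethyl group on the phenyl ring, with the same atoms, gives a number 73 percentage points lower from compound 2 to compound 4 (beyond the scatter), so the level depends on where that group sits and not on its presence. Exchanging the whole group gives a number 7 percentage points higher from compound 1 to compound 4 (within the scatter), which leaves 2-(hydroxymethyl)phenyl alone among these three groups on the aromatic nitrogen. Nothing at hand explains the gap between the two hydroxymethylphenyl groups.

Open, from the compounds shown here alone, is whether an aminomethyl group, a carboxylic acid or a longer chain such as 2-hydroxyethyl, in place of the hydroxymethyl of compound 2 , keeps the level.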